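Two Aryl Piperazines Linked by Ethane: Predicting a Fourth

The source may report more compounds than this note shows. Statements on the series, on what has been measured and on what is new or still open speak of the compounds shown alone.

Measured compounds:
Compound 1 `COc1ccccc1N1CCN(CCN2CCN(c3ccccc3OC)CC2)CC1`: 40000 nM
Compound 2 `COc1ccccc1N1CCN(CCN2CCN(c3ccc([N+](=O)[O-])cc3)CC2)CC1`: 46500 nM
Compound 3 `O=[N+]([O-])c1ccc(N2CCN(CCN3CCN(c4ccc(F)cc4)CC3)CC2)cc1`: 77900 nM

All three were tested in a functional assay on LNCaP cells (Homo sapiens) for cytotoxicity, read by MTT assay, with a stated time of 24 h; on this read-out lower numbers stand for an effect already at smaller amounts and higher numbers for an effect only at larger amounts of compound. Compound 1 gives 40000 nM, compound 2 gives 46500 nM, and compound 3 gives 77900 nM. Every pair lies within the usual scatter: a 1.2-fold lower number from compound 2 to compound 1 (0.07 log units; within the scatter) and a 1.7-fold higher number from compound 2 to compound 3 (0.22 log units; within the scatter), so no order among the three can be claimed.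

Compound 4 `COc1ccccc1N1CCN(CCN2CCN(c3ccc(F)cc3)CC2)CC1` has not yet been measured. It differs from compound 3 by one change, (2-methoxyphenyl in place of 4-nitrophenyl on an amine nitrogen in a ring). The same change has already been made once, from compound 2 to compound 1, where it is described as 2-methoxyphenyl in place of 4-nitrophenyl on an amine nitrogen in a ring and gave a 1.2-fold lower number from compound 2 to compound 1 (0.07 log units; within the scatter). The two places are described in the same words, so this is the same change. The cores of compound 3 and compound 2 differ by 4-fluorophenyl in place of 2-methoxyphenyl on an amine nitrogen in a ring.

Because the earlier step was a 1.2-fold lower number from compound 2 to compound 1 (0.07 log units; within the scatter), the step from compound 3 to compound 4 in this assay is expected to be small as well, about a 1.2-fold lower number from compound 3 to compound 4 (0.08 log units; within the scatter). Compound 4 is therefore estimated at 65000 nM, with a likely range from 35000 nM to 120000 nM.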

Compound 4, half-maximal effective concentration: 78700 nM
The estimate for compound 4 lay 1.2-fold (0.08 log units) below the measured number; the range from low to high includes it.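

In this assay, putting 2-methoxyphenyl in place of 4-nitrophenyl gave a 1.0-fold higher number from compound 3 to compound 4 (0.00 log units; within the scatter), and this step agrees with the one seen earlier on the other core: the same change on two cores in this assay, a 1.2-fold lower number (0.07 log units; within the scatter) from compound 2 to compound 1 and a 1.0-fold higher number (0.00 log units; within the scatter) from compound 3 to compound 4, 1.2-fold (0.07 log units) apart, within the scatter of two such steps
Putting fluoro in place of nitro gave a 1.7-fold higher number from compound 2 to compound 4 (0.23 log units; within the scatter), and putting 4-fluorophenyl in place of 2-methoxyphenyl gave a 2.0-fold higher number from compound 1 to compound 4 (0.29 log units; within the scatter), the latter agreeing with its earlier counterpart: the same change on two cores in this assay, a 1.7-fold higher number (0.22 log units; within the scatter) from compound 2 to compound 3 and a 2.0-fold higher number (0.29 log units; within the scatter) from compound 1 to compound 4, 1.2-fold (0.07 log units) apart, within the scatter of two such steps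
Going by these compounds alone, each repeated change therefore behaved alike on both cores, but every step here lies within the scatter, so this shows only that neither change had a measurable effect on either core, not that a change with a real effect would carry over in the same way.

With all these steps so small, the compounds shown leave open what, if anything, in this series moves the number beyond the scatter. An amine or a carboxylic acid on the aromatic ring, or a longer chain in place of the ethane link, could test this.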